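The source may hold more compounds than are shown below. What is called first, only, known or untested is meant among the compounds shown, and "the series" means these compounds.

For the measured compounds named here, compound 3 `CCCCC(CC)CNc1ncc(C(=O)O)c2nc(-c3ccco3)nn12` gives 16400 nM in an assay on CHO cells for displacement of a labelled ligand from adenosine receptor A3 (Homo sapiens) (a higher number here means a weaker inhibitor, a lower number a stronger inhibitor), the highest of the three numbers so far: compound 1 `CCOC(=O)c1cnc(NC2CCCC2)n2nc(-c3ccco3)nc12` gives 35 nM and compound 2 `CCOC(=O)c1cnc(N(C)C)n2nc(-c3ccco3)nc12` gives 275 nM. Going by the values given here, compound 3 differs from both in more than one place, so no single step reaches it. Compound 4 `O=C(O)c1cnc(NCc2ccc(Cl)cc2)n2nc(-c3ccco3)nc12` carries 4-chlorophenyl in place of 1-ethylpentyl on a saturated chain carbon bound to a nitrogen on an aromatic ring. Among the compounds with values here, the only measured step at the amine, a 7.9-fold higher number from compound 1 to compound 2 (0.90 log units; beyond the scatter), shows that this position moves the number modestly, though on a different core. Nothing measured shows a ring entering at this place, so the direction is uncertain; a modest move in either direction is expected, with the middle set by the step of a 2.7-fold lower number from compound 3 to compound 4 (0.44 log units; beyond the scatter). Compound 4 is therefore estimated at 6000 nM in this assay, between 1000 nM and 40000 nM.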

Compound 4, inhibition constant: 11600 nM
Compound 4: the middle estimate sits 1.9-fold (0.29 log units) below what was measured; the measured number falls inside the stated range.
By their numbers in this assay, from the lowest: compound 1; then compound 2; then compounds 4 and 3 (each within the scatter of the next).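

With the carboxylic acid in place, 4-chlorophenyl in place of 1-ethylpentyl gives a 1.4-fold lower number from compound 3 to compound 4 (0.15 log units; within the scatter) in this assay. At this place, on a saturated chain carbon bound to a nitrogen on an aromatic ring, the branched chain and the ring are therefore not told apart, whereas the earlier amine step on the ester was beyond the scatter. No evidence on hand bears on this result.

Still open, going by these compounds, is whether the amine groups separate with a primary amide in place of the carboxylic acid. Also open, on these data alone, is whether an unsubstituted phenyl or a methoxyphenyl matches 4-chlorophenyl here.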